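Shifting the hydroxy group on the 2-oxopiperidin-1-yl ring

The compounds below may be only part of what the source reports. "The series", "measured", "known", "first", "only" and "open" are said of these compounds alone.

Measured in an ADME assay on microsomes from liver (Rattus norvegicus) for metabolic stability, read by LC-MS, using NADPH, with a stated time of 30 min, tested at 1 uM (on this read-out lower numbers stand for slow clearance and higher numbers for fast clearance), so far:
- compound 1 `CCc1cnc(N2CCC(C(C)COC(=O)N3CCc4cc(S(C)(=O)=O)cc(F)c43)CC2)nc1` gives 365 mL.min-1.g-1 here
- compound 2 `CC(C)c1noc(N2CCC(Oc3cc(N4CCc5cc(N6CC(O)CCC6=O)ccc54)ncn3)CC2)n1` gives 7 mL.min-1.g-1 here

Compound 2 holds the lower of the two numbers, and the gap to compound 1 lies beyond the scatter. Among the measured compounds shown here, no measured pair differs in one place only, so the series offers no direct precedent for the next change.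

Compound 3 `CC(C)c1noc(N2CCC(Oc3cc(N4CCc5cc(N6CCC(O)CC6=O)ccc54)ncn3)CC2)n1` has the same atoms as compound 2, joined differently: 4-hydroxy-2-oxopiperidin-1-yl in place of 5-hydroxy-2-oxopiperidin-1-yl on an aromatic carbon on an aromatic carbon of a six-membered aromatic ring of carbon only.

For the measured compounds named here, the expectation rests on compound 2 at 7 mL.min-1.g-1 as the only close neighbour. A small upward move within the scatter is expected in this assay, with a 1.3-fold higher number from compound 2 to compound 3 (0.11 log units; within the scatter) as the estimated step. The expected value for compound 3 is 9 mL.min-1.g-1 with an estimated range from 4 mL.min-1.g-1 to 20 mL.min-1.g-1 on measurement.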

Compound 3, intrinsic clearance in microsomes: 13 mL.min-1.g-1
Compound 3: the middle estimate sits 1.4-fold (0.16 log units) below what was measured; the range from low to high includes it.
By their numbers in this assay, from the lowest: compounds 2 and 3 (each within the scatter of the next); then compound 1.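

In this assay the series now has its first step at a single place: a 1.9-fold higher number from compound 2 to compound 3 (0.27 log units; within the scatter) for 4-hydroxy-2-oxopiperidin-1-yl in place of 5-hydroxy-2-oxopiperidin-1-yl on the same aromatic carbon. The two placements of the hydroxy group therefore cannot be told apart on this read-out, and this one pair gives no sign that clearance depends on which of the two is present. No measurement at hand bears on the reason for this result.

Both compounds carry a hydroxy group on this ring, so its contribution cannot be separated from that of the ring itself. Open questions are how the plain 2-oxopiperidin-1-yl ring would read here, and how a methoxy group, an amine or a carboxylic acid would read in place of the hydroxy group.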